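A few compounds are considered here, and "the series" means these few. Any claim that something is new, unique, unknown or untested is made for them only; others in the source may bear on it.

Compound 3 `CC(C)(Oc1ccccc1)C1OCC(C/C=C\CCC(=O)O)C(c2cccnc2)O1` gives 75.9 nM in a functional assay for inhibition, with Homo sapiens as the target (on this read-out higher numbers stand for weaker binding and lower numbers for tighter binding), the lowest of the three numbers. Compound 1 `O=C(O)CC/C=C\CC1COC(c2ccccc2Cl)OC1c1cccnc1` gives 759 nM and compound 2 `O=C(O)CC/C=C\CC1COC(c2ccc([N+](=O)[O-])cc2)OC1c1cccnc1` gives 933 nM. The steps of a 10-fold lower number from compound 1 to compound 3 (1.00 log units; beyond the scatter) and a 12-fold lower number from compound 2 to compound 3 (1.09 log units; beyond the scatter) both exchange the aryl group on the saturated ring carbon, while a 1.2-fold higher number from compound 1 to compound 2 (0.09 log units; within the scatter). Compound 4 `CC(C)(Cc1ccc(F)cc1)C1OCC(C/C=C\CCC(=O)O)C(c2cccnc2)O1` differs from compound 3 by 4-fluorobenzyl in place of phenoxy on a saturated chain carbon bound to two saturated chain carbons and a saturated ring carbon. Going by the values given here, no measured step touches this chain position, so the earlier steps give only the scale of aryl exchanges and no direction for this one. The step expected in this assay is a 1.3-fold higher number from compound 3 to compound 4 (0.12 log units; within the scatter), not beyond the scatter. Compound 4 is estimated at 100 nM, with a range from 30 nM to 350 nM.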

Compound 4, dissociation constant: 89.1 nM
Beside the measured number, compound 4's estimate is 1.1-fold (0.05 log units) above it; low and high end bracket the measured number.
By their numbers in this assay, from the lowest: compounds 3 and 4 (each within the scatter of the next); then compounds 1 and 2 (each within the scatter of the next).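

On the saturated chain carbon bound to two saturated chain carbons and a saturated ring carbon, this assay shows a 1.2-fold higher number from compound 3 to compound 4 (0.07 log units; within the scatter) for 4-fluorobenzyl in place of phenoxy. This position therefore accepts loss of the phenoxy oxygen, with its hydrogen-bond acceptor, and one more heavy atom without a change beyond the scatter. No supporting data bear on why this exchange leaves the number within the scatter.

As far as these compounds go, how an amine, a carboxylic acid or plain benzyl would read at this position remains open. From the compounds shown here alone, whether the fluorine contributes at all also remains open.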